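Thiazole for phenyl in a histamine guanidine series

The source may report more compounds than this note shows. Statements on the series, on what has been measured and on what is new or still open speak of the compounds shown alone.

The three measured compounds share a core that carries an imidazole-bearing chain and a guanidine. Compound 1 `N=C(NCCCc1c[nH]cn1)NCCC(c1ccc(F)cc1)c1ccccn1` gives 100% in a functional assay on cardiac atrium for agonist activity at histamine H2 receptor (Cavia porcellus); a lower number here means a smaller maximal response, a higher number a larger maximal response. Compound 2 `N=C(NCCCc1c[nH]cn1)NC(=O)CC(c1ccccc1)c1ccccc1` gives 85% in this assay, and compound 3 `N=C(NCCCc1c[nH]cn1)NC(=O)C(c1ccccc1)c1ccccc1` gives 69%. Compound 2 thus stands second highest of the three numbers: the nearest neighbour, compound 1, lies higher by a margin beyond the usual scatter, and the furthest, compound 3, lies lower by a margin also beyond the scatter.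

Compound 4 `N=C(NCCCc1c[nH]cn1)NC(=O)CC(c1ccccc1)c1nccs1` has not yet been measured. It differs from compound 2 in one place: 1,3-thiazol-2-yl in place of phenyl on a saturated chain carbon bound to an aromatic carbon and a saturated chain carbon. Within the data shown here, no step between two measured compounds matches this change, so the size of the step must be guessed; the ring that leaves and the ring that enters are both aromatic, and the chain is unchanged, so only a small step, within the scatter, is expected in this assay, if anything a slight downward one. Compound 4 is therefore expected to give about 80% in this assay, within a range from 60% to 100%, which means an expected step of a number 5 percentage points lower from compound 2 to compound 4 (within the scatter).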

Compound 4, largest response reached (Emax), in percent of the reference or control that the assay uses: 100%
For compound 4 the middle estimate is 20 percentage points below the measured one, within the range that was stated.
By their numbers in this assay, from the lowest: compound 3; then compound 2; then compounds 1 and 4 (each within the scatter of the next).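

In this assay the exchange of phenyl for 1,3-thiazol-2-yl on this saturated chain carbon gives a number 15 percentage points higher from compound 2 to compound 4 (beyond the scatter), so swapping one aromatic ring for another at this place is not a silent change. Among these compounds, until now no pair of compounds differing in one place had been available, and this step is the first direct sign that the ring at this position bears on the maximal response. No measurement at hand accounts for the size or direction of this step.

The compounds shown do not tell whether the step goes with the ring nitrogen, the ring sulfur or the smaller ring; thiophen-2-yl and 1,3-oxazol-2-yl at the same place would separate these. They also leave open whether 1,3-thiazol-2-yl in place of the remaining phenyl would change the response further.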